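Pyrazole chalcones with methoxyphenyl groups: cytotoxicity on melanoma cells

A few compounds are considered here, and "the series" means these few. Any claim that something is new, unique, unknown or untested is made for them only; others in the source may bear on it.

Measured so far:
compound 1, `COc1cc(-c2cc(/C=C/C(=O)c3ccc(N)cc3)[nH]n2)cc(OC)c1OC`: -92%
compound 2, `COc1ccc(-c2cc(/C=C/C(=O)c3ccc(OC)c(OC)c3)[nH]n2)cc1`: -100%
compound 3, `COc1ccc(-c2cc(/C=C/C(=O)c3cc(OC)c(OC)c(OC)c3)[nH]n2)cc1OC`: -80%

In a functional assay on UACC-62 cells (Homo sapiens) for cytotoxicity, read by sulforhodamine B assay, with a stated time of 48 h, tested at 100 uM (on this read-out higher numbers stand for a weaker effect at the one concentration tested and lower numbers for a stronger effect), compound 1 gives -92%, the second highest of the three numbers. Compound 2 with -100% lies within the scatter of compound 1, so the two cannot be told apart. Compound 3 at -80% is the furthest from compound 1, beyond the scatter, and shows the weaker effect of the set; all three nevertheless sit deep in the range of strong effects at the one concentration tested.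

Compound 4, `COc1ccc(C(=O)/C=C/c2cc(-c3cc(OC)c(OC)c(OC)c3)n[nH]2)cc1OC`, has not yet been measured. Its difference from compound 1 is 3,4-dimethoxyphenyl in place of 4-aminophenyl on a carbonyl carbon. The 4-aminophenyl leaves the carbonyl carbon and a 3,4-dimethoxyphenyl enters there; the rest of the shared core is unchanged.

Compound 2 already carries a 3,4-dimethoxyphenyl on its carbonyl carbon and gives -100%, so a large shift is not expected. For compound 4 the step of a number 1 percentage points lower from compound 1 to compound 4 (within the scatter) is expected to stay within the scatter, with no direction beyond it. The value of compound 4 in this assay is thus estimated at -93%, within a range from -105% to -78%.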

Compound 4, a percentage reported as activity, at one concentration (the size of the read-out at that concentration, not a potency): -93%
The estimate for compound 4 equals the measured number at the digits printed; measured number inside the range.
By their numbers in this assay, from the lowest: compounds 2, 4 and 1 (each within the scatter of the next); then compound 3.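

Going by these compounds alone, on the carbonyl carbon, the exchange of 4-aminophenyl for 3,4-dimethoxyphenyl gives the first one-place comparison, and in this assay the step is a number 1 percentage points lower from compound 1 to compound 4 (within the scatter) for this pair. At this one concentration, the hydrogen-bond donor of the 4-aminophenyl is thus not required at this position, since the 3,4-dimethoxyphenyl carries none and the two compounds cannot be told apart. Nothing at hand gives a measured reason for this result.

A single concentration at which both compounds sit deep in the range of strong effects leaves open whether their potencies differ. Also open, from the compounds shown here alone, is how far this position tolerates other groups, such as an unsubstituted phenyl, a carboxylic acid on the ring or a longer chain in place of the ring.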